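The source may hold more compounds than are shown below. What is called first, only, known or untested is meant among the compounds shown, and "the series" means these compounds.

Compound 3 `CNC(=O)c1cc(C(=O)N[C@H]2[C@@H]3COC[C@@H]32)cc2c1OC[C@H]2C1CCOCC1`: >= 177 ug/mL
Compound 1 `CNC(=O)c1cc(C(=O)N[C@H]2[C@@H]3COC[C@@H]32)cc2c1OC[C@H]2c1cccc(OC)c1`: >= 186 ug/mL
Compound 2 `CNC(=O)c1cc(C(=O)N[C@H]2[C@@H]3COC[C@@H]32)cc2c1OC[C@H]2c1cccnc1`: >= 104 ug/mL

In a physicochemical assay for solubility (on this read-out lower numbers stand for lower solubility and higher numbers for higher solubility), compound 3 gives only a limit of the assay, not a number, so its standing among the three cannot be fixed. The values of compound 1 and compound 2 are limits as well. The change to compound 4 `CNC(=O)c1cc(C(=O)N[C@H]2[C@@H]3COC[C@@H]32)cc2c1OC[C@H]2c1ccncc1` is pyridin-4-yl in place of oxan-4-yl on a saturated ring carbon. Among the measured compounds shown here, the steps that bear on it are a step that the two limits leave unreadable from compound 2 to compound 3 and a step that the two limits leave unreadable from compound 1 to compound 3, and both were left unreadable by the limits, so no size or direction beyond the scatter can be read from them. The step from compound 3 to compound 4 is therefore expected to be an at least 1.1-fold lower number from compound 3 to compound 4 (0.07 log units; that floor lies within the scatter), and the result may again be a limit. Compound 4 is expected to give 150 ug/mL, within 60 ug/mL to 350 ug/mL.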

Compound 4, solubility: >= 184 ug/mL
Compound 4: no number, only a limit (the forecaster's own chance of this, stated with the estimate: 70%); middle value at least 1.2-fold (0.08 log units) away from the limit.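

In this assay compound 4 gives only a limit, as do compound 1, compound 2 and compound 3, and none of the steps to compound 4 can be read. The compounds shown leave open how the four rank, and whether exchanging these groups changes the read-out at all.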